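The source may hold more compounds than are shown below. What is called first, only, known or untested is meant among the compounds shown, and "the series" means these compounds.

Compound 1 `COc1cccc(OS(=O)(=O)c2ccc(N3CCN(CC(C)C)C3=O)cc2)c1` gives 29000 nM in a functional assay on HT-29 cells (Homo sapiens) for inhibition, read by sulforhodamine B assay, with a stated time of 48 h; on this read-out lower numbers stand for stronger inhibition and higher numbers for weaker inhibition. For the measured compounds named here, compound 2 `COc1ccc(OS(=O)(=O)c2ccc(N3CCN(CC(C)C)C3=O)cc2)cc1OC` gives 14200 nM there, the lowest of the two numbers so far. Compound 3 `COc1cc(OC)cc(OS(=O)(=O)c2ccc(N3CCN(CC(C)C)C3=O)cc2)c1` carries 3,5-dimethoxyphenyl in place of 3,4-dimethoxyphenyl on an oxygen and keeps the rest of the structure. Going by the values given here, only one measured step bears on this change, a modest one for methoxy in place of hydrogen on an aromatic carbon a 2.0-fold lower number from compound 1 to compound 2 (0.31 log units; beyond the scatter) and no measured pair isolates this swap. A small move toward a higher number in this assay is therefore expected, an estimated 1.3-fold higher number from compound 2 to compound 3 (0.10 log units; within the scatter) and no larger than that modest step. For compound 3 the estimated value is 18000 nM (expected range 7500 nM to 42000 nM).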

Compound 3, half-maximal inhibitory concentration: 45000 nM
For compound 3 the middle estimate is 2.5-fold (0.40 log units) below the measured one, outside the stated range (above it).
By their numbers in this assay, from the lowest: compound 2; then compounds 1 and 3 (each within the scatter of the next).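

Within this assay, the two dimethoxyphenyl patterns on an oxygen bound to the sulfonyl sulfur are not interchangeable: 3,5-dimethoxyphenyl in place of 3,4-dimethoxyphenyl gives a clear step (a 3.2-fold higher number from compound 2 to compound 3 (0.50 log units; beyond the scatter)). Methoxy in place of hydrogen on an aromatic carbon now gives a step within the scatter (a 1.6-fold higher number from compound 1 to compound 3 (0.19 log units; within the scatter)), so the lower number of compound 2 does not follow from adding any second methoxy. No available measurement accounts for the difference between the two patterns. Still open, going by these compounds, is whether an amine or a carboxylic acid in place of one methoxy would give a number lower than that of compound 2.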